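Furan-3-yl for Thiophen-2-yl: One Change, One Expectation

This account rests on a few compounds, and the source may have more. Where it says the series, first, only, none or still open, it means among the compounds named here.

Within the data shown here, of the two numbers so far in an assay on isolated protein for inhibition of DNA topoisomerase 1 (Homo sapiens), with a stated time of 30 min, tested at 100 uM (a higher number here means a stronger effect of the compound at the concentration tested, a lower number a weaker effect), compound 2 `Oc1cccc(-c2cc(-c3cccs3)cc(-c3cccc(O)c3)n2)c1` gives 91.7% and compound 1 `Oc1cccc(-c2cc(-c3cccs3)cc(-c3ccccc3O)n2)c1` gives 83.2%; the step of a number 8.5 percentage points higher from compound 1 to compound 2 (within the scatter) is within the scatter, so the two stand level. Compound 3 `Oc1cccc(-c2cc(-c3ccoc3)cc(-c3cccc(O)c3)n2)c1` differs from compound 2 in one place: furan-3-yl in place of thiophen-2-yl on an aromatic carbon. Among the measured compounds shown here, no measured step alters this five-membered ring; the only known step, a number 8.5 percentage points higher from compound 1 to compound 2 (within the scatter), concerns another part of the shared core and offers no direct guide. The expected step of a number 5.7 percentage points lower from compound 2 to compound 3 (within the scatter) is therefore none beyond the scatter. For compound 3 the estimate is 86%, expected between 65% and 98%.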

Compound 3, a percentage reported as inhibition, at one concentration (the size of the read-out at that concentration, not a potency): 44.2%
Compound 3: middle estimate off by 41.8 percentage points, on the high side; measured number outside the range, below it.
By their numbers in this assay, from the lowest: compound 3; then compounds 1 and 2 (each within the scatter of the next).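

Putting furan-3-yl in place of thiophen-2-yl, opposite the ring nitrogen, gives a number 47.5 percentage points lower from compound 2 to compound 3 (beyond the scatter) in this assay. The two groups have the same number of heavy atoms, the same ring size and the same hydrogen-bond donor and acceptor counts, so those counts alone do not settle the read-out at this position. No measurement given here explains the drop. Furan-2-yl and thiophen-3-yl would separate the effect of the hetero atom from that of the ring's point of attachment. As far as these compounds go, how a phenyl or an amine would read at this position also remains open.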